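The source may report more compounds than this note shows. Statements on the series, on what has been measured and on what is new or still open speak of the compounds shown alone.

Measured compounds:
compound 1, `Nc1ncnc2c1c(Oc1cc(C(F)(F)F)ccn1)nn2C1CCCC1`: 0.333 h
compound 2, `Nc1ncnc2c1c(Oc1cccc(Cl)c1)nn2[C@H]1C[C@H](F)C1`: 0.153 h

Of the compounds shown here, two built on a shared core have been measured in an ADME assay on microsomes from liver (Homo sapiens) for metabolic stability, read by LC-MS, using NADPH, with a stated time of 10 min, tested at 10 uM; a lower number here means that the compound disappears faster, a higher number that the compound lasts longer. Compound 1 gives 0.333 h, the higher of the two numbers. Compound 2 gives 0.153 h, a lower number, and the gap between the two values lies beyond the usual scatter. These two compounds differ in more than one place, so nothing beyond what the two values show is said of that pair.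

Compound 3, `Nc1ncnc2c1c(Oc1cc(C(F)(F)F)ccn1)nn2C1CCC1`, has not yet been measured in this assay. It differs from compound 1 in one place: cyclobutyl in place of cyclopentyl on an aromatic nitrogen. For the measured compounds named here, no step between measured compounds carries this change, so the expectation for compound 3 rests on compound 1 alone. Compound 3 is expected to stay close to compound 1, with the step of a 1.2-fold higher number from compound 1 to compound 3 (0.08 log units; within the scatter) estimated as small and not beyond the scatter. The estimate for compound 3 is 0.4 h, in the range 0.2 h to 0.8 h.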

Compound 3, half-life: 1.02 h
For compound 3 the middle estimate is 2.6-fold (0.41 log units) below the measured one; measured number above the stated range.
By their numbers in this assay, from the lowest: compound 2; then compound 1; then compound 3.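

In this assay the group on the aromatic nitrogen can move the number by itself: cyclobutyl in place of cyclopentyl gives a 3.1-fold higher number from compound 1 to compound 3 (0.49 log units; beyond the scatter) while the rest of compound 1 stays the same. The earlier compounds shown here could not show this, as compound 1 and compound 2 differ in more than one place. No measurement shown here accounts for the size or direction of this step.

With only these two groups compared directly on this nitrogen, the compounds shown leave open how a cyclopropyl ring, an isopropyl group or a ring carrying an amine would compare with cyclobutyl. They also leave open whether the same change would give a step of similar size with the chlorophenoxy group of compound 2 in place of the trifluoromethyl-bearing group.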